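Working notes: amine swap and Vero cell cytotoxicity

The compounds below may be only part of what the source reports. "The series", "measured", "known", "first", "only" and "open" are said of these compounds alone.

compound 1 `O=c1nc(NCc2ccc(F)cc2)oc2c([N+](=O)[O-])cc(C(F)(F)F)cc12` — > 64 ug/mL
compound 2 `O=c1nc(NC2CCCCC2)oc2c([N+](=O)[O-])cc(C(F)(F)F)cc12` — 5.39 ug/mL
compound 3 `O=c1cc(NC2CCCCC2)sc2c([N+](=O)[O-])cc(C(F)(F)F)cc12` — > 64 ug/mL

In an ADME assay on Vero cells (Chlorocebus sabaeus) for cytotoxicity, read by MTT assay, with a stated time of 48 h (on this read-out lower numbers stand for stronger inhibition and higher numbers for weaker inhibition), compound 2 gives 5.39 ug/mL. For compound 1 the value > 64 ug/mL is a limit of this assay, not a number. For compound 3 the value > 64 ug/mL is likewise a limit. The change 4-fluorobenzyl in place of cyclohexyl on a nitrogen on an aromatic ring produced an at least 11-fold higher number from compound 2 to compound 1 (1.07 log units; beyond the scatter). The cores of compound 2 and compound 3 differ, but that difference is not broken down here. Compound 4 `O=c1cc(NCc2ccc(F)cc2)sc2c([N+](=O)[O-])cc(C(F)(F)F)cc12` carries the same change from compound 3, (4-fluorobenzyl in place of cyclohexyl on a nitrogen on an aromatic ring), at a place described in the same words. Because (the limit of > 64 ug/mL in this assay, at which 2 of the 3 values shown sit), most of the series already sits at the limit. Compound 4 is expected to give 90 ug/mL. For compound 4 the expected step is a step that the limit leaves unreadable from compound 3 to compound 4. This rests on compound 3 standing at a limit and on an at least 11-fold higher number from compound 2 to compound 1 (1.07 log units; beyond the scatter), which moved the number upward.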

Compound 4, half-maximal inhibitory concentration: > 64 ug/mL
Compound 4: only a limit was reported; the forecaster's own chance of this, stated with the estimate: 85%; the middle value is on the limit's open side.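

In this assay compound 4 gives > 64 ug/mL, which is a limit and not a number. With compound 3 also at a limit, the step to compound 4 cannot be read. Still open, on these data alone, is whether 4-fluorobenzyl in place of cyclohexyl changes the number on the core of compound 3 as it does on the core of compound 2.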